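Bromo for nitro on the aryl ring: expected recovery

The source may hold more compounds than are shown below. What is called first, only, known or untested is meant among the compounds shown, and "the series" means these compounds.

In a functional assay on the whole organism with Mus musculus as the target, with a stated time of 1 h, at a dose of 100 mg/kg by the intraperitoneal route (on this read-out lower numbers stand for less inhibition and higher numbers for more inhibition at the one dose given (going by the name of the read-out)), compound 1 `c1ccc(COc2nc3ccccc3s2)cc1` gives 68.8%. Compound 2 `O=[N+]([O-])c1ccc(COc2nc3ccccc3s2)cc1` gives 4.39%, the lowest of the three numbers, and compound 3 `Clc1cccc(COc2nc3ccccc3s2)c1` gives 80%. The measured steps are a number 64.4 percentage points lower from compound 1 to compound 2 (beyond the scatter) and a number 11.2 percentage points higher from compound 1 to compound 3 (beyond the scatter). Compound 4 `Brc1ccc(COc2nc3ccccc3s2)cc1` differs from compound 2 by bromo in place of nitro on an aromatic carbon. Both steps bear on this change: the large fall seen when nitro replaced hydrogen is expected to reverse once the nitro leaves, and the modest gain with chloro in compound 3, 80%, suggests a halogen on this ring sits at or somewhat above the level of compound 1. A large rise in this assay is therefore expected, about a number 69.6 percentage points higher from compound 2 to compound 4 (beyond the scatter). For compound 4 the estimate is 74%, within 50% to 92%.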

Compound 4, a percentage reported as inhibition, in the whole organism at one dose (the size of the read-out at that dose, not a potency): 78%
Estimate against measurement, compound 4: 4 percentage points below; the measured number falls inside the stated range.
By their numbers in this assay, from the lowest: compound 2; then compounds 1, 4 and 3 (each within the scatter of the next, the first and the last beyond it).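

In this assay, bromo para to a large group does not carry the loss seen with nitro at that place, with a number 73.6 percentage points higher from compound 2 to compound 4 (beyond the scatter) as the step. Against the unsubstituted compound, the reading is a number 9.2 percentage points higher from compound 1 to compound 4 (within the scatter), so the low number of compound 2 belongs to nitro and not to substitution at this place as such. Nothing measured here gives a reason for the gap between nitro and bromo.

On these data alone, whether a nitrile, an amine or a carboxylic acid at this place would fall with nitro or stay with bromo remains open.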